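Replacing 3,4-dimethoxyphenyl with 4-bromophenyl in compound 2

A few compounds are considered here, and "the series" means these few. Any claim that something is new, unique, unknown or untested is made for them only; others in the source may bear on it.

Compound 1 `COc1ccccc1/C=C/C(=O)OC/C=C/c1cc(OC)c(OC)cc1OC`: 294 umol/kg
Compound 2 `COc1cc(OC)c(OC)cc1/C=C/COC(=O)/C=C/c1ccc(OC)c(OC)c1`: 225 umol/kg
Compound 3 `COc1cc(OC)c(OC)cc1/C=C/COC(=O)/C=C/c1c(OC)ccc(OC)c1OC`: >= 180 umol/kg, a limit of the assay

These results come from a functional assay on the whole organism (strain Kunming) with Mus musculus as the target, in the formalin test, with a stated time of 0.5 h; a lower number here means that less compound is needed, a higher number that more compound is needed for the effect. Compound 2 stands at 225 umol/kg, within the scatter of compound 1. For compound 3, this assay gives only a limit, >= 180 umol/kg.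

The next compound, compound 4 `COc1cc(OC)c(OC)cc1/C=C/COC(=O)/C=C/c1ccc(Br)cc1`, carries 4-bromophenyl in place of 3,4-dimethoxyphenyl on a double-bonded chain carbon bound to a double-bonded chain carbon. Within the data shown here, one measured step bears on this place: a 1.3-fold lower number from compound 1 to compound 2 (0.12 log units; within the scatter), with 3,4-dimethoxyphenyl in place of 2-methoxyphenyl. It is a single step, and 4-bromophenyl is new among the measured compounds, so the guide is thin. On that evidence, no change beyond the scatter is expected in this assay, in either direction. The expected size is a 1.1-fold lower number from compound 2 to compound 4 (0.05 log units; within the scatter). For compound 4 the estimated value is 200 umol/kg, with an expected range from 90 umol/kg to 430 umol/kg.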

Compound 4, dose for half-maximal effect: 243 umol/kg
Estimate against measurement, compound 4: 1.2-fold (0.08 log units) below; the range from low to high includes it.
By their numbers in this assay, from the lowest: compounds 2, 4 and 1 (each within the scatter of the next).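

In this assay, this place on a double-bonded chain carbon bound to a double-bonded chain carbon accepts a group with no hydrogen-bond acceptors: 4-bromophenyl in place of 3,4-dimethoxyphenyl gives a 1.1-fold higher number from compound 2 to compound 4 (0.03 log units; within the scatter). Put in place of 2-methoxyphenyl, the same group gives a 1.2-fold lower number from compound 1 to compound 4 (0.08 log units; within the scatter), so a bromine-bearing ring and two methoxy-bearing rings now stand within the scatter of one another. Steps to compound 3 cannot be read, as its value is a limit: the limit of >= 180 umol/kg in this assay, at which 1 of the 4 values shown sits.

No measurement shown bears on why these three groups give such similar numbers. From the compounds shown here alone, it remains open whether a group of another kind at this place, such as an amine or a carboxylic acid, would move the number beyond the scatter.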